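This account rests on a few compounds, and the source may have more. Where it says the series, first, only, none or still open, it means among the compounds named here.

Measured compounds:
Compound 1, `c1ccc(-c2cn3ccnc3c(-c3ccc4ncn(C5CCCCC5)c4c3)n2)cc1`, in a functional assay on SNB-75 cells (Homo sapiens) for inhibition, read by sulforhodamine B assay, with a stated time of 48 h, tested at 10 uM (on this read-out lower numbers stand for less inhibition and higher numbers for more inhibition at the one concentration tested (going by the name of the read-out)), gives 44.4%.
Compound 2, `COc1ccccc1-c1cn2ccnc2c(-c2ccc3ncn(C4CCCCC4)c3c2)n1`, in this assay gives 35%.

Among the compounds with values here, compound 2 stands lowest of the two numbers, and its only neighbour is compound 1, from which it differs by a number 9.4 percentage points lower from compound 1 to compound 2 (within the scatter), a change of methoxy in place of hydrogen on an aromatic carbon that does not rise above the scatter. The unmeasured compound 3, `c1csc(-c2cn3ccnc3c(-c3ccc4ncn(C5CCCCC5)c4c3)n2)c1`, differs from compound 2 by thiophen-2-yl in place of 2-methoxyphenyl on an aromatic carbon. Within the data shown here, no measured step replaces the whole 2-methoxyphenyl ring with a five-membered ring, so the one step at hand bears only loosely on it; that step was small. With the numbers of compound 1 and compound 2 so close, no step beyond the scatter is expected in this assay, and compound 3 is estimated at 40%, between 20% and 60%, an expected step of a number 5 percentage points higher from compound 2 to compound 3 (within the scatter).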

Compound 3, a percentage reported as inhibition, at one concentration (the size of the read-out at that concentration, not a potency): 8.13%
Beside the measured number, compound 3's estimate is 31.9 percentage points above it, outside the stated range (below it).
By their numbers in this assay, from the lowest: compound 3; then compounds 2 and 1 (each within the scatter of the next).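

In this assay, the position next to the ring nitrogen proves sensitive to the identity of the ring it carries: thiophen-2-yl in place of phenyl gives a number 36.3 percentage points lower from compound 1 to compound 3 (beyond the scatter), and thiophen-2-yl in place of 2-methoxyphenyl gives a number 26.9 percentage points lower from compound 2 to compound 3 (beyond the scatter). The earlier methoxy step stayed within the scatter, so only now does a change at this position register, and among these three compounds the two bearing a six-membered aromatic ring of carbon stand apart from the one bearing the five-membered ring with sulfur. No measurement at hand accounts for this drop.

The compounds shown leave open whether the drop follows the smaller ring or the sulfur atom, a question that furan-2-yl could address. They also leave open whether thiophen-3-yl, joined to the core through a different ring carbon, would behave like thiophen-2-yl.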